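The source may hold more compounds than are shown below. What is called first, only, known or untested is meant among the compounds shown, and "the series" means these compounds.

Measured compounds in the series:

compound 1 `O=C(Nc1cccc(/C=C/C(=O)c2nc3ccccc3[nH]2)c1)c1cccc(Br)c1` — in a functional assay on 143B cells (Homo sapiens) for antiproliferative activity, read by MTT assay, with a stated time of 48 h (on this read-out lower numbers stand for stronger inhibition and higher numbers for weaker inhibition), compound 1 gives 4620 nM
compound 2 `O=C(Nc1cccc(/C=C/C(=O)c2nc3ccccc3[nH]2)c1)c1ccc(Br)cc1` — compound 2 gives 7310 nM
compound 3 `Cc1ccc(C(=O)Nc2cccc(/C=C/C(=O)c3nc4ccccc4[nH]3)c2)cc1` — compound 3 gives 6560 nM

Compound 2 stands at the highest of the three numbers, but all three lie close together: the nearest is compound 3, a 1.1-fold lower number from compound 2 to compound 3 (0.05 log units; within the scatter), and the furthest is compound 1, a 1.6-fold higher number from compound 1 to compound 2 (0.20 log units; within the scatter). Among the compounds with values here, nothing among the measured compounds separates from the others beyond the scatter.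

Compound 4 `Cc1ccc(S(=O)(=O)Nc2cccc(/C=C/C(=O)c3nc4ccccc4[nH]3)c2)cc1` is not yet measured in this assay. It differs from compound 2 by (4-methylphenyl)sulfonyl in place of (4-bromophenyl)carbonyl on a nitrogen on an aromatic ring. Of the measured steps, only a 1.1-fold lower number from compound 2 to compound 3 (0.05 log units; within the scatter) bears on it, covering the methyl in place of bromo part of the change, and that step was within the scatter. Within the data shown here, no measured pair exchanges a carbonyl for a sulfonyl on the nitrogen, so that part of the change is untested here. On the evidence at hand, no step beyond the scatter is expected, and the step is estimated as a 1.1-fold lower number from compound 2 to compound 4 (0.05 log units; within the scatter), with a wide range to allow for the untested sulfonyl. Compound 4 is therefore expected to give about 6500 nM, within 2000 nM to 20000 nM.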

Compound 4, half-maximal inhibitory concentration: 3220 nM
Estimate against measurement, compound 4: 2.0-fold (0.31 log units) above; the range from low to high includes it.
By their numbers in this assay, from the lowest: compounds 4, 1, 3 and 2 (each within the scatter of the next, the first and the last beyond it).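

Sulfonyl in place of carbonyl on the nitrogen is the first change in the series to move the number beyond the scatter in this assay: with the 4-methylphenyl held constant, it gives a 2.0-fold lower number from compound 3 to compound 4 (0.31 log units; beyond the scatter), and the change from (4-bromophenyl)carbonyl gives a 2.3-fold lower number from compound 2 to compound 4 (0.36 log units; beyond the scatter). The gain is modest and does not separate the sulfonyl from every carbonyl, as compound 1 goes against it with a 1.4-fold lower number from compound 1 to compound 4 (0.16 log units; within the scatter), so the effect of this exchange depends on the aryl group compared. Nothing measured on these compounds accounts for the step.

As far as these compounds go, whether the sulfonyl keeps this edge with a 3-bromophenyl or 4-bromophenyl group on it remains open. So does the response of this position to a sulfonyl bearing a carboxylic acid, an amine or a longer alkyl chain in place of the aryl ring.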